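A few compounds are considered here, and "the series" means these few. Any claim that something is new, unique, unknown or untested is made for them only; others in the source may bear on it.

In a functional assay on HL-60 cells (Homo sapiens) for inhibition, read by MTT assay, with a stated time of 72 h (on this read-out lower numbers stand for stronger inhibition and higher numbers for weaker inhibition), compound 1 (`CO[C@@H]1[C@H]2OC(=O)C[C@H]2O[C@@H]1[C@@H](O)c1ccccc1`) gives 19000 nM. Compound 2 (`CO[C@@H]1[C@H]2OC(=O)C[C@H]2O[C@@H]1C(=O)c1ccccc1`) gives 11200 nM, which lies within the usual scatter of compound 1. Compound 3 (`CO[C@@H]1[C@H]2OC(=O)C[C@H]2O[C@@H]1C(O)(c1ccccc1)c1ccccc1`) gives 2360 nM, a clearly lower number and beyond that scatter. Compound 4 (`CO[C@@H]1[C@H]2OC(=O)C[C@H]2O[C@@H]1[C@H](O)c1ccccc1`) is reached from compound 1 by a single change: the two compounds have the same atoms and bonds and differ only in configuration as drawn: 1 of 5 stereo elements differ; a stereocentre at a saturated chain carbon is drawn S in compound 1 and R in compound 4. Going by the values given here, no measured pair here shows what such a change does, so the only guide is the spread already seen. Among the compounds with values here, with compound 3 at 2360 nM as the one number clearly apart from compound 1, a large move seems unlikely. In this assay, the expected step is a 1.7-fold lower number from compound 1 to compound 4 (0.24 log units; within the scatter), which should stay within the usual scatter. The estimated value for compound 4 is 11000 nM, with an expected range of 3500 nM to 30000 nM.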

Compound 4, half-maximal inhibitory concentration: 25000 nM
The estimate for compound 4 lay 2.3-fold (0.36 log units) below the measured number, within the range that was stated.
By their numbers in this assay, from the lowest: compound 3; then compounds 2, 1 and 4 (each within the scatter of the next, the first and the last beyond it).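

In this assay, switching the stereocentre at a saturated chain carbon from S to R gives a 1.3-fold higher number from compound 1 to compound 4 (0.12 log units; within the scatter), so this inversion alone leaves the number inside the usual scatter. None of the earlier compounds could test configuration at this carbon on its own, and this pair can because nothing else changes: the fact that compounds 1 and 4 differ only in the configuration as drawn

As far as these compounds go, whether this configuration would matter as little with an amine in place of the hydroxyl remains open. From the compounds shown here alone, the contribution of the other stereo elements also remains open.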